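The compounds below may be only part of what the source reports. "The series", "measured", "known", "first", "only" and "open" are said of these compounds alone.

Compound 1 `O=C1C(=O)N(CN(c2ccccc2)c2ccccc2)c2cccc(Cl)c21` gives 14400 nM in a functional assay on MDA-MB-468 cells (Homo sapiens) for cytotoxicity, read by sulforhodamine B assay, with a stated time of 48 h; a higher number here means a weaker inhibitor of growth, a lower number a stronger inhibitor of growth; among the two numbers shown it sits at the top, though only by a margin inside the scatter. Compound 2 `CCN(CC)CN1C(=O)C(=O)c2c(Br)cccc21` gives 11700 nM in this assay, so the two values cannot be separated. Compound 3 `O=C1C(=O)N(CN(c2ccccc2)c2ccccc2)c2cccc(Br)c21` differs from compound 1 by bromo in place of chloro on an aromatic carbon. Going by the values given here, no measured pair shows this exchange, so the expected step in this assay is none beyond the scatter, in either direction: a 1.1-fold lower number from compound 1 to compound 3 (0.04 log units; within the scatter). Compound 3 is therefore estimated at 13000 nM, with a range from 5500 nM to 31000 nM.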

Compound 3, concentration for 50% growth inhibition: 63300 nM
For compound 3 the middle estimate is 4.9-fold (0.69 log units) below the measured one; measured number outside the range, above it.
By their numbers in this assay, from the lowest: compounds 2 and 1 (each within the scatter of the next); then compound 3.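

In this assay, bromo in place of chloro on this aromatic carbon gives a 4.4-fold higher number from compound 1 to compound 3 (0.64 log units; beyond the scatter), so the two halogens are not interchangeable at this place on the core of compound 1, although the step is modest. Going by these compounds alone, the exchange therefore weakens growth inhibition here, a difference the earlier compounds could not show. No measurement available bears on the origin of this step. Still open, as far as these compounds go, is whether the same exchange would give a similar step on the core of compound 2. Also open, from the compounds shown here alone, is how fluoro, methyl or a nitrile would read at this place.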